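Branching the Ester Chain Further: What to Expect

This account rests on a few compounds, and the source may have more. Where it says the series, first, only, none or still open, it means among the compounds named here.

Compound 2 `CCOC(=O)C1=C(C)NC(C)=C(C(=O)OCC(C)C)C1c1csc(-c2ccc(Cl)cc2)n1` was tested in an assay on isolated protein for antagonist activity at Voltage-dependent L-type calcium channel subunit alpha-1C (Cavia porcellus), with a stated time of 15 min; a lower number here means a stronger inhibitor, a higher number a weaker inhibitor; compound 2 gives 15400 nM, the highest of the two numbers recorded so far. Its nearest neighbour, compound 1 `CCOC(=O)C1=C(C)NC(C)=C(C(=O)OCC)C1c1csc(-c2ccc(Cl)cc2)n1`, gives 3650 nM in this assay. Among the measured compounds shown here, the only measured step, a 4.2-fold higher number from compound 1 to compound 2 (0.63 log units; beyond the scatter), also changed this ester chain. Compound 3 `CCOC(=O)C1=C(C)NC(C)=C(C(=O)OC(C)(C)C)C1c1csc(-c2ccc(Cl)cc2)n1` goes one step further: tert-butyl in place of isobutyl on an oxygen next to a carbonyl group, with the same atoms joined differently. Since that earlier step moved the number upward by a modest amount, a further modest rise is expected for compound 3, an expected step of a 1.4-fold higher number from compound 2 to compound 3 (0.15 log units; within the scatter). The expected value for compound 3 is 22000 nM, with a range from 6000 nM to 80000 nM.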

Compound 3, half-maximal inhibitory concentration: 91000 nM
Estimate against measurement, compound 3: 4.1-fold (0.62 log units) below; the measured number lies above the stated range.
By their numbers in this assay, from the lowest: compound 1; then compound 2; then compound 3.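

In this assay, tert-butyl in place of isobutyl gives a 5.9-fold higher number from compound 2 to compound 3 (0.77 log units; beyond the scatter), so at this ester oxygen the arrangement of the chain matters even when its atoms stay the same. Tert-butyl in place of ethyl gives a 25-fold higher number from compound 1 to compound 3 (1.40 log units; beyond the scatter), and the number rises across all three compounds in the order ethyl, isobutyl, tert-butyl. Nothing in the available data addresses the reason for this rise. From the compounds shown here alone, whether a methyl ester or a longer straight chain ending in an amine would lower the number at this position remains open.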